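The compounds below may be only part of what the source reports. "The series", "measured", "known", "first", "only" and "open" are said of these compounds alone.

Compounds measured so far:
- compound 1, `CC(C)(C)c1ccc(NC(=O)c2ccc(-c3cccnc3)cc2)cc1`: 1300 nM
- compound 2, `CC(C)(C)c1ccc(NC(=O)c2ccc(-c3ncccn3)cc2)cc1`: 60 nM
- compound 3, `CC(C)(C)c1ccc(NC(=O)c2ccc(-c3cncnc3)cc2)cc1`: 10000 nM

All three share one core and differ only in the aromatic ring attached to it. In a functional assay on Dorsal root ganglion for antagonist activity at transient receptor potential cation channel subfamily V member 1 (Rattus norvegicus) (a higher number here means a weaker inhibitor, a lower number a stronger inhibitor), compound 3 gives the highest number of the three, so it is the weakest inhibitor here. The nearest is compound 1, with a 7.7-fold higher number from compound 1 to compound 3 (0.89 log units; beyond the scatter); the furthest is compound 2, with a 170-fold higher number from compound 2 to compound 3 (2.22 log units; beyond the scatter).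

Compound 4, `Cc1cccnc1-c1ccc(C(=O)Nc2ccc(C(C)(C)C)cc2)cc1`, is not yet measured. Relative to compound 3 the change is 3-methylpyridin-2-yl in place of pyrimidin-5-yl on an aromatic carbon. Within the data shown here, of the known steps, the most relevant is the one between compound 2 and compound 3, since pyrimidin-2-yl and 3-methylpyridin-2-yl both carry "2-yl" in their names and so are joined to the core in the same way, and that step was large. The step from compound 1 to compound 3 was modest. Among the measured compounds shown here, a large drop in the number is therefore expected in this assay, though the methyl group has no precedent among the measured compounds, so the size is uncertain. Compound 4 is estimated at 200 nM, with a range from 40 nM to 1500 nM, an expected step of a 50-fold lower number from compound 3 to compound 4 (1.70 log units; beyond the scatter).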

Compound 4, half-maximal inhibitory concentration: 31 nM
Compound 4: the middle estimate sits 6.5-fold (0.81 log units) above what was measured; the whole stated range lies above it.
By their numbers in this assay, from the lowest: compounds 4 and 2 (each within the scatter of the next); then compound 1; then compound 3.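

In this assay, the change to 3-methylpyridin-2-yl gives the largest step seen so far at this position (a 320-fold lower number from compound 3 to compound 4 (2.51 log units; beyond the scatter)), and it also separates clearly from the pyridin-3-yl ring (a 42-fold lower number from compound 1 to compound 4 (1.62 log units; beyond the scatter)). Against the pyrimidin-2-yl ring there is no readable difference (a 1.9-fold lower number from compound 2 to compound 4 (0.29 log units; within the scatter)), so a ring with one hetero atom and a methyl group does as well here as a ring with two hetero atoms and no methyl group. Across these four compounds, the two rings with "2-yl" in their names give lower numbers than the 3-yl and 5-yl rings, and no compound goes against this.

Going by these compounds, what plain pyridin-2-yl would give, and so what the methyl group itself adds, stays open, as does the effect of an ethyl, a methoxy or an amine in its place. Nothing available explains these differences.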